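Selenium for sulfur in a bis-acyl isothiourea series

A few compounds are considered here, and "the series" means these few. Any claim that something is new, unique, unknown or untested is made for them only; others in the source may bear on it.

Compound 1 `CS/C(=N\C(=O)c1ccno1)NC(=O)c1ccno1` and compound 2 `C[Se]/C(=N\C(=O)c1ccno1)NC(=O)c1ccno1` share a core. In a functional assay on PC-3 cells (Homo sapiens) for cytotoxicity, read by MTT assay, with a stated time of 72 h (a higher number here means a weaker inhibitor of growth, a lower number a stronger inhibitor of growth), compound 1 reaches only a limit, > 100000 nM. In this assay compound 2 gives 39300 nM. The change a group of 2 heavy atoms (1 carbon, 1 selenium; no ring) in place of a group of 2 heavy atoms (1 carbon, 1 sulfur; no ring), on a carbon with a double bond to nitrogen produced an at least 2.5-fold lower number from compound 1 to compound 2 (0.40 log units; beyond the scatter); its size is open at one end, given (the limit of > 100000 nM in this assay, at which 2 of the 3 values shown sit).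

Compound 3 `CS/C(=N\C(=O)c1cc(-c2ccccc2)nc2ccccc12)NC(=O)c1cc(-c2ccccc2)nc2ccccc12` carries another core; how it differs from the core of compound 1 is not broken down here. In this assay compound 3 reaches only a limit, > 100000 nM. Compound 4 `C[Se]/C(=N\C(=O)c1cc(-c2ccccc2)nc2ccccc12)NC(=O)c1cc(-c2ccccc2)nc2ccccc12` differs from compound 3 by a group of 2 heavy atoms (1 carbon, 1 selenium; no ring) in place of a group of 2 heavy atoms (1 carbon, 1 sulfur; no ring), on a carbon with a double bond to nitrogen, the same change as between compound 1 and compound 2, at a place described in the same words.

The step is expected to be an at least 1.6-fold lower number from compound 3 to compound 4 (0.22 log units; that floor lies within the scatter), resting on an at least 2.5-fold lower number from compound 1 to compound 2 (0.40 log units; beyond the scatter). Compound 4 is estimated at 60000 nM, between 20000 nM and 300000 nM.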

Compound 4, concentration for total growth inhibition: 40200 nM
The estimate for compound 4 lay 1.5-fold (0.17 log units) above the measured number; the measured number falls inside the stated range.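

Replacing methylsulfanyl with its selenium counterpart, on a carbon with a double bond to nitrogen, again gives a change in this assay, with an at least 2.4-fold lower number from compound 3 to compound 4 (0.39 log units; beyond the scatter). The lower number therefore carries over in direction from the core of compound 1 to the core of compound 3, but its size cannot be compared: the same change on two cores in this assay, an at least 2.5-fold lower number (0.40 log units; beyond the scatter) from compound 1 to compound 2 and an at least 2.4-fold lower number (0.39 log units; beyond the scatter) from compound 3 to compound 4; the limit leaves it open whether they differ The sulfur compounds give limits rather than numbers, so neither step has a fixed size: the limit of > 100000 nM in this assay, at which 2 of the 4 values shown sit.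

The compounds shown leave open whether the change holds with a longer chain in place of the methyl group. They also leave open whether it holds on a core carrying an amine or a carboxylic acid.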